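The source may hold more compounds than are shown below. What is called first, only, known or untested is meant among the compounds shown, and "the series" means these compounds.

Measured so far:
- compound 1, `O=C(O)c1ccc(N2C(=O)N/C(=C\c3ccc(O)cc3)C2=O)cc1`: in a functional assay on NCI-H292 cells (Homo sapiens) for antiproliferative activity (on this read-out higher numbers stand for weaker inhibition and lower numbers for stronger inhibition), compound 1 gives > 200000 nM, a limit of the assay.
- compound 2, `O=C(c1cccc(N2C(=O)N/C(=C\c3ccc(O)cc3)C2=O)c1)N1CCCC1`: in this assay compound 2 gives > 200000 nM, likewise only a limit.

Compound 1 therefore stands at the ceiling of the numbers shown, with no measured value for it; both values recorded sit at the same limit (the limit of > 200000 nM in this assay, at which 2 of the 2 values shown sit). Within the data shown here, no step between measured compounds is available.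

Compound 3, `O=C(c1ccc(N2C(=O)N/C(=C\c3ccc(O)cc3)C2=O)cc1)N1CCCC1`, differs from compound 1 by pyrrolidin-1-yl in place of hydroxy on a carbonyl carbon. Compound 2 carries the same (pyrrolidin-1-yl)carbonyl group, and in this assay compound 2 gives > 200000 nM, which is itself only a limit of the assay, so the amide alone has not yielded a measured number.

Among the measured compounds shown here, with only limits at hand, no step in this assay beyond the scatter can be expected in either direction; the change from compound 1 to compound 3 is estimated as a step that the limit leaves unreadable from compound 1 to compound 3. Compound 3 is expected to give about 250000 nM in this assay, in the range 50000 nM to 1000000 nM, most likely again reported only as a limit.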

Compound 3, half-maximal inhibitory concentration: > 200000 nM
Compound 3 gave a limit, no number; the forecaster's own chance of this, stated with the estimate: 85%; the middle value is on the limit's open side.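

Compound 1 and compound 3 both stand at a limit and not at a number, so no step can be read from the one to the other: the limit of > 200000 nM in this assay, at which 3 of the 3 values shown sit.

Going by these compounds, whether any compound reaches a measured number in this assay stays open, and with it how carboxy and (pyrrolidin-1-yl)carbonyl compare.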